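A few compounds are considered here, and "the series" means these few. Any claim that something is new, unique, unknown or untested is made for them only; others in the source may bear on it.

Measured so far, in a functional assay on A549 cells (Homo sapiens) for inhibition, read by MTT assay, with a stated time of 72 h, tested at 10 uM; on this read-out lower numbers stand for less inhibition and higher numbers for more inhibition at the one concentration tested (going by the name of the read-out):
- compound 1 `CCOC(=O)C1=C(Nc2ccccc2)S/C(=C\c2ccc(OC)cc2)C1=O` gives 17.5%.
- compound 2 `CCOC(=O)C1=C(Nc2ccccc2)S/C(=C\c2cccc(C(=O)O)c2)C1=O` reaches only the assay limit, < 10%.
- compound 3 `CCOC(=O)C1=C(Nc2ccccc2)S/C(=C\c2ccc[nH]2)C1=O` gives 23.5%.

Compound 3 stands highest of the two numbers in this assay; the nearest is compound 1, and the difference a number 6 percentage points higher from compound 1 to compound 3 (within the scatter) is within the scatter, so no order between them can be claimed. Compound 2 sits at the limit (the limit of < 10% in this assay, at which 1 of the 3 values shown sits); the step of a number at least 13.5 percentage points higher from compound 2 to compound 3 (beyond the scatter) is beyond the scatter.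

Compound 4 `CCOC(=O)C1=C(Nc2ccc(OC)cc2)S/C(=C\c2ccc[nH]2)C1=O` differs from compound 3 by methoxy in place of hydrogen on an aromatic carbon. Within the data shown here, every measured step changes the group on the double-bonded chain carbon; none touches the anilino ring, so no measured step bears directly on this change. For compound 4 the expected step is a number 1.5 percentage points higher from compound 3 to compound 4 (within the scatter) in this assay, not beyond the scatter. Compound 4 is therefore estimated at 25%, with a range from 10% to 45%.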

Compound 4, a percentage reported as inhibition, at one concentration (the size of the read-out at that concentration, not a potency): < 10%
Compound 4 gave a limit, no number (the forecaster's own chance of this, stated with the estimate: 15%); at least 15 percentage points between middle value and limit.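

In this assay, the first change measured on the six-membered aromatic ring, methoxy in place of hydrogen para to a large group, gives a number at least 13.5 percentage points lower from compound 3 to compound 4 (beyond the scatter). This position therefore responds to substitution, at least with the 1H-pyrrol-2-yl group held constant. Compound 4 reads < 10%, which is a limit and not a number: the limit of < 10% in this assay, at which 2 of the 4 values shown sit.

As far as these compounds go, whether an amine or a carboxylic acid at this place would track compound 3 or compound 4 remains open. Also open, from the compounds shown here alone, is whether methoxy has the same effect with another group on the double-bonded chain carbon.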